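Phenyl for iodo on two related nucleoside cores

The source may report more compounds than this note shows. Statements on the series, on what has been measured and on what is new or still open speak of the compounds shown alone.

Compound 2 `Cc1nc(N)c2c(I)cn([C@@H]3O[C@H](CO)[C@@H](O)[C@H]3O)c2n1` carries an iodo group on the five-membered ring, and in a functional assay on HeLa S3 cells (Homo sapiens) for antiproliferative activity, read by XTT assay, with a stated time of 72 h (on this read-out higher numbers stand for weaker inhibition and lower numbers for stronger inhibition), compound 2 gives 4180 nM. Compound 1 `Cc1nc(N)c2c(-c3ccccc3)cn([C@@H]3O[C@H](CO)[C@@H](O)[C@H]3O)c2n1` differs from it by phenyl in place of iodo on an aromatic carbon. Compound 1 reaches only a limit in this assay, > 20000 nM. The step of an at least 4.7-fold higher number from compound 2 to compound 1 (0.67 log units; beyond the scatter) therefore counts as at least modest. Compound 3 `CNc1ncnc2c1c(I)cn2[C@@H]1O[C@H](CO)[C@@H](O)[C@H]1O` keeps the iodo group but sits on another core; the difference between the two cores is not broken down here. Compound 3 in this assay gives only a limit, > 20000 nM. Compound 4 `CNc1ncnc2c1c(-c1ccccc1)cn2[C@@H]1O[C@H](CO)[C@@H](O)[C@H]1O` arises from compound 3 by the same change, (phenyl in place of iodo on an aromatic carbon). Because compound 3 already sits at the limit of > 20000 nM in this assay, at which 2 of the 3 values shown sit, compound 4 is expected to give only a limit as well, so that the step that the limit leaves unreadable from compound 3 to compound 4 would itself be seen only as a bound. Compound 4 is estimated at 60000 nM, within 20000 nM to 300000 nM.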

Compound 4, half-maximal inhibitory concentration: > 20000 nM
Compound 4: only a limit was reported (the forecaster's own chance of this, stated with the estimate: 95%); the middle value lies beyond the limit too.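

No step can be read between compound 3 and compound 4, since each gives only a limit in this assay: the limit of > 20000 nM in this assay, at which 3 of the 4 values shown sit.

The compounds shown leave open what phenyl in place of iodo does on the core of compound 3.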